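A Larger Sulfonamide Group on a Weak Compound

The source may hold more compounds than are shown below. What is called first, only, known or untested is meant among the compounds shown, and "the series" means these compounds.

In a functional assay on the whole organism (strain Sprague-Dawley) for inhibition, with Rattus norvegicus as the target, with a stated time of 10 min (on this read-out lower numbers stand for an effect already at smaller amounts and higher numbers for an effect only at larger amounts of compound), compound 1 `CCOc1ccc(OC)cc1-c1ncc(C(=O)O)c(=O)[nH]1` gives 0.2 mg/kg, and compound 2 `CCOc1ccc(N)cc1-c1ncc(C(=O)O)c(=O)[nH]1` gives 1.2 mg/kg. Compound 3 `CCOc1ccc(S(=O)(=O)N(C)C)cc1-c1ncc(C(=O)O)c(=O)[nH]1` is recorded only as a limit, > 50 mg/kg, which places it at the weak end of the three. Putting dimethylsulfamoyl in place of methoxy gives an at least 250-fold higher number from compound 1 to compound 3 (2.39 log units; beyond the scatter), and putting it in place of amino gives an at least 41-fold higher number from compound 2 to compound 3 (1.61 log units; beyond the scatter). Both steps are large.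

Compound 4 `CCOc1ccc(S(=O)(=O)N(C)C(C)C)cc1-c1ncc(C(=O)O)c(=O)[nH]1` changes one spot: isopropyl in place of methyl on a sulfonamide nitrogen. Among the compounds with values here, no measured step alters this nitrogen, so those two large steps bear on the change only indirectly. They show how weak this assay finds compound 3, and compound 4 still carries a sulfamoyl group. The step expected is a number no higher from compound 3 to compound 4 (the limit leaves the size open), with no shift beyond the usual scatter anticipated in either direction, and a further report of only a limit is likely. For compound 4 the estimated dose is 50 mg/kg, expected to fall in the range from 15 mg/kg to 150 mg/kg.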

Compound 4, dose for 50% inhibition: > 10 mg/kg
Compound 4 gave a limit, no number; the forecaster's own chance of this, stated with the estimate: 75%; the middle value lies beyond the limit too.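

In this assay, putting isopropyl(methyl)sulfamoyl on the aromatic carbon gives an at least 50-fold higher number from compound 1 to compound 4 (1.69 log units; beyond the scatter), and it gives an at least 8.3-fold higher number from compound 2 to compound 4 (0.92 log units; beyond the scatter), so a second sulfamoyl group, now with a larger chain on its nitrogen, also falls on the weak side of methoxy and amino. The change itself, isopropyl in place of methyl on a sulfonamide nitrogen, cannot be read because compound 4 rests on a limit: the limit of > 10 mg/kg in this assay, at which 1 of the 4 values shown sits.
Compound 3 also rests on a limit: the limit of > 50 mg/kg in this assay, at which 1 of the 4 values shown sits.

As far as these compounds go, whether isopropyl on this nitrogen raises, lowers or leaves unchanged the dose needed remains open, as neither compound 3 nor compound 4 has an exact number. Also open, from the compounds shown here alone, is how this assay would respond to a sulfonamide nitrogen carrying a longer chain, or to a morpholine ring in place of the dimethylamino part.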